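Chloro to azido: estimating compound 3

The source may report more compounds than this note shows. Statements on the series, on what has been measured and on what is new or still open speak of the compounds shown alone.

Compound 1 `C/C=C/C(=O)N(Cc1cc(OC)c(OC)c(OC)c1)c1ccc(OC)c(O)c1` gives 9160 nM
Compound 2 `COc1ccc(N(Cc2cc(OC)c(OC)c(OC)c2)C(=O)CCl)cc1O` gives 29800 nM

In a functional assay on KYSE-450 cells (Homo sapiens) for inhibition, read by MTT assay, with a stated time of 48 h (a higher number here means a weaker inhibitor, a lower number a stronger inhibitor), compound 2 29800 nM is the weaker inhibitor of the two measured compounds. The next compound to test is compound 3 `COc1ccc(N(Cc2cc(OC)c(OC)c(OC)c2)C(=O)CN=[N+]=[N-])cc1O`, which differs from compound 2 by one change: azido in place of chloro on a saturated chain carbon bound to a carbonyl carbon.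

Among the measured compounds shown here, only one measured step bears on this change: a 3.3-fold higher number from compound 1 to compound 2 (0.51 log units; beyond the scatter). For the measured compounds named here, that modest step altered the same end of the molecule, but no measured compound carries azido, so it offers only a rough guide to size. No step beyond the scatter is therefore expected in this assay, and the direction remains uncertain. The estimated step is a 1.5-fold lower number from compound 2 to compound 3 (0.17 log units; within the scatter) and could plausibly fall on either side. For compound 3 the estimated value is 20000 nM, with an expected range from 7000 nM to 60000 nM in this estimate.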

Compound 3, half-maximal inhibitory concentration: 26100 nM
Compound 3: middle estimate off by 1.3-fold (0.12 log units), on the low side; the measured number falls inside the stated range.
By their numbers in this assay, from the lowest: compound 1; then compounds 3 and 2 (each within the scatter of the next).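

In this assay, azido in place of chloro on a saturated chain carbon bound to a carbonyl carbon gives a result that cannot be told from no change (a 1.1-fold lower number from compound 2 to compound 3 (0.06 log units; within the scatter)), even though azido brings 3 heavy atoms where chloro has 1. Compound 1, with its prop-1-en-1-yl group, stays ahead of the azidomethyl compound too (a 2.8-fold higher number from compound 1 to compound 3 (0.45 log units; beyond the scatter)), as it did of the chloromethyl compound (a 3.3-fold higher number from compound 1 to compound 2 (0.51 log units; beyond the scatter)). Nothing available explains these numbers.

As far as these compounds go, whether an amine or a carboxylic acid on this chain carbon would shift the number remains open. So does whether a longer chain in place of azidomethyl would bring the activity back towards that of compound 1.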